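A few compounds are considered here, and "the series" means these few. Any claim that something is new, unique, unknown or untested is made for them only; others in the source may bear on it.

Series values in a functional assay on DU-145 cells (Homo sapiens) for inhibition, read by trypan blue exclusion, with a stated time of 96 h; a higher number here means a weaker inhibitor of growth, a lower number a stronger inhibitor of growth:

- compound 1 `O=C(/C(=C\c1ccc(OC(F)(F)F)cc1)S(=O)(=O)c1ccc(Br)cc1)c1ccc(Br)cc1` gives 25000 nM
- compound 2 `O=C(/C(=C\c1ccc(I)cc1)S(=O)(=O)c1ccc(Br)cc1)c1ccc(Br)cc1` gives 1000 nM
- compound 3 `COc1ccc(/C=C(/Sc2ccc(Br)cc2)C(=O)c2ccc(Cl)cc2)cc1` gives 50000 nM

Compound 2 holds the lowest number of the three, and both other values lie beyond the scatter from it. The next compound, compound 4 `O=C(/C(=C\c1ccc(Br)c([N+](=O)[O-])c1)S(=O)(=O)c1ccc(Br)cc1)c1ccc(Br)cc1`, carries a change at the same place: 4-bromo-3-nitrophenyl in place of 4-iodophenyl on a double-bonded chain carbon bound to a double-bonded chain carbon.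

Going by the values given here, one measured step bears on this place: a 25-fold lower number from compound 1 to compound 2 (1.40 log units; beyond the scatter). This large step shows that the group here can move the number strongly in this assay. Among the compounds with values here, it is only one pair, however, and no measured compound carries 4-bromo-3-nitrophenyl. Compound 3 differs from compound 2 in more than one place and gives no clean comparison.

Within the data shown here, with compound 2 at 1000 nM as the lowest number so far, a move to a higher number is expected, though probably a smaller one than the measured step. The expected change is a 3.0-fold higher number from compound 2 to compound 4 (0.48 log units; beyond the scatter). For compound 4 the estimated value is 3000 nM, with an expected range of 500 nM to 20000 nM.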

Compound 4, concentration for 50% growth inhibition: 10000 nM
Compound 4: the middle estimate sits 3.3-fold (0.52 log units) below what was measured; the measured number falls inside the stated range.
By their numbers in this assay, from the lowest: compound 2; then compound 4; then compounds 1 and 3 (each within the scatter of the next).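

In this assay, 4-bromo-3-nitrophenyl in place of 4-iodophenyl gives a 10-fold higher number from compound 2 to compound 4 (1.00 log units; beyond the scatter), so a second replacement on a double-bonded chain carbon bound to a double-bonded chain carbon also moves the number beyond the scatter. Both replacements of the 4-iodophenyl group now raise the number, as read alongside a 25-fold lower number from compound 1 to compound 2 (1.40 log units; beyond the scatter), and compound 2 keeps the lowest value among these three compounds that differ at this place. No measurement given here explains the effect of either group.

The new step changes the halogen and adds the nitro group together, so the contribution of each remains unresolved. As far as these compounds go, it also remains open how an amine or a carboxylic acid on this aromatic ring would behave, and whether any group here could bring the number below that of compound 2.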